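Adding a Methyl Group to Compound 1: What to Expect

The compounds below may be only part of what the source reports. "The series", "measured", "known", "first", "only" and "open" are said of these compounds alone.

Three compounds have so far been measured in a functional assay on HeLa cells (Homo sapiens) for cytotoxicity, read by MTT assay, with a stated time of 72 h, tested at 3 uM; on this read-out lower numbers stand for less inhibition of growth and higher numbers for more inhibition of growth at the one concentration tested:

Compound 1 `N/C(=N\NC(=S)N1CCCCCC1)c1ccccn1` gives 36.6%.
Compound 2 `N/C(=N\NC(=S)N1CCN(c2ccccn2)CC1)c1ccc(F)cn1` gives 77.3%.
Compound 3 `Cc1cccc(/C(N)=N/NC(=S)N2CCCCC2)n1` gives 68.9%.

Among these three numbers, compound 1 stands lowest. The nearest to it is compound 3, whose number lies higher by an amount beyond the scatter of repeated measurements, and the furthest is compound 2, whose number lies higher by an even larger amount, also beyond the scatter. Compound 1 is thus the weakest of the three at inhibiting the growth of these cells.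

The next compound to consider is compound 4 `Cc1ccnc(/C(N)=N/NC(=S)N2CCCCCC2)c1`. It differs from compound 1 in a single place: methyl in place of hydrogen on an aromatic carbon. Everything else in the molecule is kept, including the seven-membered ring attached to the thiourea part.

Among the compounds with values here, no pair of measured compounds differs in only one place, so there is no directly comparable step to draw on. Compound 3 also carries a methyl group on its aromatic ring, at a different place and with a different ring on the thiourea side, and gives 68.9%, which leaves room for a methyl group to raise the number. The expectation is a modest rise a number 9.4 percentage points higher from compound 1 to compound 4 (within the scatter) in this assay, but one that may not clear the scatter. Compound 4 is therefore estimated at 46%, within a range from 28% to 68%.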

Compound 4, percent growth inhibition at one concentration: 41.9%
Beside the measured number, compound 4's estimate is 4.1 percentage points above it; the range from low to high includes it.
By their numbers in this assay, from the lowest: compounds 1 and 4 (each within the scatter of the next); then compounds 3 and 2 (each within the scatter of the next).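

Within the data shown here, this is the first comparison in the set where only one place in the molecule changes, so it can be read directly. In this assay, putting methyl in place of hydrogen on this aromatic carbon, meta to a large group and opposite the ring nitrogen, gives a step of a number 5.3 percentage points higher from compound 1 to compound 4 (within the scatter), so the two compounds cannot be told apart on this read-out, and with the seven-membered ring kept, this change at this place shows no clear effect on the growth of these cells. Nothing available explains this outcome, and no separate measurement bears on why the step is so small.

The compounds shown leave open whether a methyl group on a different carbon of the same aromatic ring would give a step beyond the scatter. They also leave open whether a larger or different group at this same place, such as a methoxy group, an amine or a longer chain, would move the number any further than methyl does.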